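The source may hold more compounds than are shown below. What is called first, only, known or untested is meant among the compounds shown, and "the series" means these compounds.

Compound 1 `COc1cc(Cl)cc(-c2nn(-c3cccc(NC(=O)Nc4ccc(Cl)c(Cl)c4)c3)cc2-c2ccncc2)c1` carries a 3,4-dichlorophenyl group on an amide-type nitrogen; compound 2 `COc1cc(Cl)cc(-c2nn(-c3cccc(NC(=O)Nc4cccc(C(F)(F)F)c4)c3)cc2-c2ccncc2)c1` carries a 3-(trifluoromethyl)phenyl group on an amide-type nitrogen. In a functional assay on DU-145 cells (Homo sapiens) for inhibition, read by sulforhodamine B assay, with a stated time of 48 h, tested at 0.1 uM (on this read-out higher numbers stand for a weaker effect at the one concentration tested and lower numbers for a stronger effect), compound 1 gives 97% and compound 2 gives 99%. Compound 2 stands at the top of the two numbers shown, but the step of a number 2 percentage points higher from compound 1 to compound 2 (within the scatter) is within the scatter, so the two compounds are not distinguished at this concentration. Compound 3 `COc1cc(Cl)cc(-c2nn(-c3cccc(NC(=O)c4cccc(C(F)(F)F)c4)c3)cc2-c2ccncc2)c1` differs from compound 2 in one place: 3-(trifluoromethyl)phenyl in place of (3-(trifluoromethyl)phenyl)amino on a carbonyl carbon. For the measured compounds named here, no measured step bears on this change directly; the only recorded step, from compound 1 to compound 2, concerns the group on an amide-type nitrogen and was within the scatter. With both measured compounds near the high end of the read-out in this assay, the step of a number 4 percentage points lower from compound 2 to compound 3 (within the scatter) is expected to be none beyond the scatter. Compound 3 is estimated in this assay at 95%, with a range from 80% to 105%.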

Compound 3, a percentage reported as activity, at one concentration (the size of the read-out at that concentration, not a potency): 107%
Compound 3: middle estimate off by 12 percentage points, on the low side; measured number outside the range, above it.
By their numbers in this assay, from the lowest: compounds 1, 2 and 3 (each within the scatter of the next).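

In this assay, 3-(trifluoromethyl)phenyl in place of (3-(trifluoromethyl)phenyl)amino on a carbonyl carbon gives a number 8 percentage points higher from compound 2 to compound 3 (within the scatter), and the same group in place of (3,4-dichlorophenyl)amino gives a number 10 percentage points higher from compound 1 to compound 3 (within the scatter). The earlier step changed only the aryl group, whereas these steps also remove the amino nitrogen and its hydrogen-bond donor from this position, and still neither separates the compounds at this one concentration. No supporting measurement is available to interpret this result.

On these data alone, it remains open whether an amine, a carboxylic acid or a longer chain in place of 3-(trifluoromethyl)phenyl on the carbonyl carbon would give a step beyond the scatter. As far as these compounds go, it also remains open whether compounds 1, 2 and 3 would separate at a larger concentration in this assay.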